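From Compound 3 to Its Methyl Counterpart, Compound 4

The source may report more compounds than this note shows. Statements on the series, on what has been measured and on what is new or still open speak of the compounds shown alone.

Compound 1 `Nc1ccccc1NC(=O)c1ccc(CSc2nc3ccc(NCc4ccccn4)cc3s2)cc1`: 1000 nM
Compound 2 `Nc1ccccc1NC(=O)c1ccc(CSc2nc3ccc(NCc4cccnc4)cc3s2)cc1`: 1000 nM
Compound 3 `Nc1ccccc1NC(=O)c1ccc(CSc2ncc[nH]2)cc1`: 5000 nM

In a functional assay on HCT-116 cells (Homo sapiens) for cytotoxicity, read by MTT assay (on this read-out higher numbers stand for weaker inhibition and lower numbers for stronger inhibition), compound 3 gives 5000 nM, the highest number of the three, beyond the scatter from both of the others. Compound 4 `Cn1ccnc1SCc1ccc(C(=O)Nc2ccccc2N)cc1` differs from compound 3 in one place: methyl in place of hydrogen on an aromatic nitrogen. In words, this is methyl in place of hydrogen on an aromatic nitrogen, so that 1H-imidazol-2-yl becomes 1-methyl-1H-imidazol-2-yl.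

Among the measured compounds shown here, only one measured step exists, no change at the digits printed from compound 1 to compound 2 (within the scatter), with pyridin-3-yl in place of pyridin-2-yl. It lies within the scatter, but it concerns a different group, so it bears on the present change only weakly. For the measured compounds named here, no measured step replaces hydrogen with methyl. Compound 1 and compound 2 have lower numbers than compound 3, but they differ from it in far more than one place, so that gap does not size this change.

With so little precedent, no step beyond the scatter is expected in this assay, and the range is left wide in both directions. The expected change is no change at the digits printed from compound 3 to compound 4 (within the scatter). For compound 4 the estimated value is 5000 nM, with an expected range of 1800 nM to 13000 nM.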

Compound 4, half-maximal inhibitory concentration: 5000 nM
The estimate for compound 4 equals the measured number at the digits printed, within the range that was stated.
By their numbers in this assay, from the lowest: compounds 1 and 2 (each within the scatter of the next); then compounds 3 and 4 (each within the scatter of the next).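

In this assay, among the compounds shown here, the replacement of hydrogen by methyl on an aromatic nitrogen gives no change at the digits printed from compound 3 to compound 4 (within the scatter) and is the only measured step at this place, since the one earlier step concerned pyridinyl groups elsewhere on a different core. It shows that this read-out does not separate 1H-imidazol-2-yl from 1-methyl-1H-imidazol-2-yl, so the hydrogen on this aromatic nitrogen can give way to one carbon, on the ring position next to the ring atom that bears a large group, without a change beyond the scatter. No measurement offered here accounts for this result, which therefore stands as an observation only.

Going by these compounds, it remains open whether a larger group on the same aromatic nitrogen, such as ethyl or a longer chain ending in an amine or a carboxylic acid, would leave the number equally unmoved. On these data alone, it also remains open whether methyl in place of hydrogen would give the same result in any other cell line or on a different core, as this is a single step in a single assay.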